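Replacing the 4-acetamidophenyl group of compound 2

The source may report more compounds than this note shows. Statements on the series, on what has been measured and on what is new or still open speak of the compounds shown alone.

In a functional assay on NCI-H460 cells (Homo sapiens) for positive allosteric modulation, read by MTT assay, with stated times of 2 h and 72 h, tested at 3 uM (a higher number here means a weaker inhibitor, a lower number a stronger inhibitor), compound 1 (`COc1ccc(C(=O)Nc2ccccc2-c2nnn(-c3ccc(OC)cc3)n2)cc1`) gives 156 nM and compound 3 (`COc1ccc(NC(=O)Nc2ccccc2-c2nnn(-c3ccc(OC)cc3)n2)cc1`) gives 229 nM. Compound 2 (`COc1cccc(-n2nnc(-c3ccccc3NC(=O)c3ccc(NC(C)=O)cc3)n2)c1`) gives 554 nM, the highest number and the weakest result of the three. Compound 4 (`COc1cccc(-n2nnc(-c3ccccc3NC(=O)Nc3ccc([N+](=O)[O-])cc3)n2)c1`) differs from compound 2 in one place: (4-nitrophenyl)amino in place of 4-acetamidophenyl on a carbonyl carbon. Among the compounds with values here, one measured step bears on this change, since it also places an arylamino group on a carbonyl carbon: a 1.5-fold higher number from compound 1 to compound 3 (0.17 log units; within the scatter). Within the data shown here, that step lies within the scatter, although no measured compound carries a 4-nitrophenyl group, so the comparison is only partial. The expected result is a 1.1-fold higher number from compound 2 to compound 4 (0.03 log units; within the scatter), which means no change beyond the scatter is anticipated. For compound 4 the estimated value is 600 nM, with an expected range of 200 nM to 1800 nM.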

Compound 4, half-maximal inhibitory concentration: 190 nM
The estimate for compound 4 lay 3.2-fold (0.50 log units) above the measured number; measured number outside the range, below it.
By their numbers in this assay, from the lowest: compounds 1, 4 and 3 (each within the scatter of the next); then compound 2.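

In this assay the group on this carbonyl carbon proves able to move the number, with a 2.9-fold lower number from compound 2 to compound 4 (0.46 log units; beyond the scatter), whereas the earlier arylamino replacement gave a 1.5-fold higher number from compound 1 to compound 3 (0.17 log units; within the scatter). This step brings in the amino link and replaces acetamido with nitro together, and the compounds shown do not separate the two changes. No evidence bears on why the number moved. Still open, as far as these compounds go, is whether an amine or a carboxylic acid in place of the nitro group would give a similar number.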